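Three Diacylhydrazides, All Beyond the Assay Limit

The source may report more compounds than this note shows. Statements on the series, on what has been measured and on what is new or still open speak of the compounds shown alone.

Measured compounds:
compound 1 `Cc1ccccc1C(=O)NNC(=O)c1cccc(NS(=O)(=O)c2cnc(O)nc2O)c1` — > 20000 nM in a functional assay on OVCAR-3 cells (Homo sapiens) for antiproliferative activity, read by MTT assay, with a stated time of 24 h (on this read-out lower numbers stand for stronger inhibition and higher numbers for weaker inhibition), a limit of the assay, not a number
compound 2 `Cc1ccc(C(=O)NNC(=O)c2cccc(NS(=O)(=O)c3cnc(O)nc3O)c2)cc1` — > 20000 nM in this assay, a limit of the assay, not a number
compound 3 `Cc1ccccc1C(=O)NNC(=O)c1ccccc1NS(=O)(=O)c1cnc(O)nc1O` — > 20000 nM in this assay, a limit of the assay, not a number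

The three compounds share a diacylhydrazide bearing a sulfonamide-substituted aryl group and differ in two ways. Compound 1 and compound 2 differ by 4-methylphenyl in place of 2-methylphenyl on a carbonyl carbon. In this assay this change gives a step that the two limits leave unreadable from compound 1 to compound 2, because both values sit at the limit of > 20000 nM in this assay, at which 3 of the 3 values shown sit. Compound 3 and compound 1 differ in their cores, and that difference is not broken down here.

Compound 4 `Cc1ccc(C(=O)NNC(=O)c2ccccc2NS(=O)(=O)c2cnc(O)nc2O)cc1` is not yet measured. It differs from compound 3 by 4-methylphenyl in place of 2-methylphenyl on a carbonyl carbon, the same change as that from compound 1 to compound 2, at the same place. In this assay the step for compound 4 is expected to be a step that the limit leaves unreadable from compound 3 to compound 4, resting on compound 3 at > 20000 nM and on compound 1 and compound 2 both at the limit of > 20000 nM in this assay, at which 3 of the 3 values shown sit, so that the same change is expected once more to stay at the limit. Compound 4 is expected to give about 35000 nM, between 12000 nM and 120000 nM.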

Compound 4, half-maximal inhibitory concentration: 12900 nM
For compound 4 the middle estimate is 2.7-fold (0.43 log units) above the measured one; measured number inside the range.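

In this assay, among the compounds shown here, 4-methylphenyl in place of 2-methylphenyl on a carbonyl carbon gives an at least 1.5-fold lower number from compound 3 to compound 4 (0.19 log units; that floor lies within the scatter), and compound 4, at 12900 nM, is the only one of the four compounds with a number and not a limit. That step has only a floor, so it does not establish that the change lowers the number on the core of compound 3. The same change on the core of compound 1 cannot be read, so the series does not show whether the change carries from one core to the other, or whether the two cores differ in their response to it: the limit of > 20000 nM in this assay, at which 3 of the 4 values shown sit.

The compounds shown leave open how large the step from compound 3 really is, and what the change does on the core of compound 1 at a level where it could be read. They also leave open whether an aminophenyl group, a carboxyphenyl group or a longer chain such as 4-ethylphenyl in place of 4-methylphenyl would give a readable number on either core.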